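A Halogen Swap on the Sulfonamide Arm

This account rests on a few compounds, and the source may have more. Where it says the series, first, only, none or still open, it means among the compounds named here.

Compound 1 `O=C1O[C@H]([C@@H](O)Cn2cc(CNS(=O)(=O)c3ccc(F)cc3)nn2)C(OCc2ccccc2)=C1OCc1ccccc1` carries a sulfonamide arm at one end of the shared core. Among the measured compounds shown here, in a functional assay on MCF7 cells (Homo sapiens) for antiproliferative activity, read by MTT assay, with a stated time of 72 h (a lower number here means a stronger inhibitor, a higher number a weaker inhibitor), compound 1 gives 26800 nM, the higher of the two numbers known, although the gap to compound 2 `O=C1O[C@H]([C@@H](O)Cn2cc(C3CC3)nn2)C(OCc2ccccc2)=C1OCc1ccccc1`, which gives 25900 nM, is within the scatter. The step of a 1.0-fold lower number from compound 1 to compound 2 (0.01 log units; within the scatter) shows that removing the whole arm in favour of cyclopropyl barely moves the read-out. Compound 3 `O=C1O[C@H]([C@@H](O)Cn2cc(CNS(=O)(=O)c3ccc(Cl)cc3F)nn2)C(OCc2ccccc2)=C1OCc1ccccc1` keeps the arm and differs from compound 1 only at its far end: 4-chloro-2-fluorophenyl in place of 4-fluorophenyl on a sulfonyl sulfur. For the measured compounds named here, no measured pair probes this particular change; the only step available concerns a much larger alteration and still sits within the scatter. A shift in this assay is therefore expected to be small, and the step of a 1.1-fold lower number from compound 1 to compound 3 (0.03 log units; within the scatter) is estimated to stay within the scatter. Compound 3 is expected to give about 25000 nM, with a range from 12000 nM to 55000 nM.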

Compound 3, half-maximal inhibitory concentration: 3390 nM
Beside the measured number, compound 3's estimate is 7.4-fold (0.87 log units) above it, and the stated range ends above it.
By their numbers in this assay, from the lowest: compound 3; then compounds 2 and 1 (each within the scatter of the next).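

In this assay, the far end of the sulfonamide arm proves able to move the read-out: 4-chloro-2-fluorophenyl in place of 4-fluorophenyl on a sulfonyl sulfur gives a 7.9-fold lower number from compound 1 to compound 3 (0.90 log units; beyond the scatter), a step beyond the scatter. Compound 1 and compound 2 sat within the scatter of each other, so that pair gave no sign that the aromatic ring on the sulfonyl sulfur could matter, and a small edit there now does more than replacing the whole arm with cyclopropyl. Nothing measured here says what lies behind this step. The compounds shown do not tell whether the chlorine alone accounts for the step or whether the different fluorine placement in 4-chloro-2-fluorophenyl also contributes. They also leave open how a bromine, a methoxy group or an amine would fare in place of that chlorine.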